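Bromo in place of chloro: an expected near-standstill

The compounds below may be only part of what the source reports. "The series", "measured", "known", "first", "only" and "open" are said of these compounds alone.

In a functional assay on HepG2 cells (Homo sapiens) for cytotoxicity, read by MTT assay, with a stated time of 24 h (a higher number here means a weaker inhibitor, a lower number a stronger inhibitor), compound 1 `COc1cc(/C=C2\CN(C)C/C(=C\c3ccc(F)cc3)C2=O)cc(OC)c1OC` gives 7340 nM and compound 2 `COc1cc(/C=C2\CN(C)C/C(=C\c3ccc(Cl)cc3)C2=O)cc(OC)c1OC` gives 8250 nM. Going by the values given here, compound 2 therefore stands within the scatter of compound 1, its only measured neighbour, and the two numbers cannot be ranked.

Compound 3 `COc1cc(/C=C2\CN(C)C/C(=C\c3ccc(Br)cc3)C2=O)cc(OC)c1OC` departs from compound 2 by a single change: bromo in place of chloro on an aromatic carbon. This places bromo in place of chloro on an aromatic carbon, para to a large group. Among the compounds with values here, one measured step bears on it, the exchange of chloro in place of fluoro on an aromatic carbon, which gave a 1.1-fold higher number from compound 1 to compound 2 (0.05 log units; within the scatter). Within the data shown here, with only that small step as a guide, no shift beyond the scatter is expected in this assay, in either direction. The expected move is a 1.0-fold higher number from compound 2 to compound 3 (0.01 log units; within the scatter). Compound 3 is estimated at about 8500 nM, with an expected range of 5000 nM to 14000 nM.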

Compound 3, half-maximal inhibitory concentration: 6800 nM
Compound 3: the middle estimate sits 1.3-fold (0.10 log units) above what was measured; low and high end bracket the measured number.
By their numbers in this assay, from the lowest: compounds 3, 1 and 2 (each within the scatter of the next).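

In this assay, the exchange of 4-chlorophenyl for 4-bromophenyl gives a 1.2-fold lower number from compound 2 to compound 3 (0.08 log units; within the scatter), and the larger exchange of fluoro for bromo gives a 1.1-fold lower number from compound 1 to compound 3 (0.03 log units; within the scatter). The earlier pair offered a single step, but fluoro, chloro and bromo can now all be compared on an aromatic carbon, para to a large group, and none of the three steps among them leaves the scatter, so these halogens cannot be told apart at this position in this assay. The data shown offer no explanation for this flat result.

On these data alone, what remains open is whether a group other than a halogen at this position, such as an amine, a hydroxyl or a carboxylic acid, would move the number beyond the scatter. As far as these compounds go, it is also open whether these halogen exchanges would read the same way on a different core.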